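The compounds below may be only part of what the source reports. "The series", "measured", "known", "first", "only" and "open" are said of these compounds alone.

Measured in a functional assay on MCF7 cells (Homo sapiens) for cytotoxicity, read by sulforhodamine B assay, with a stated time of 72 h; on this read-out lower numbers stand for stronger inhibition and higher numbers for weaker inhibition:
- compound 1 `O=C(Nc1ccc(Nc2ncnc3c2cnn3-c2ccc(Cl)cc2)cc1)Nc1ccccc1Cl`: 9050 nM
- compound 2 `O=C(NC1CCCCC1)c1ccc(Nc2ncnc3c2cnn3-c2ccc(Cl)cc2)cc1`: > 100000 nM (a limit)

Compound 2 gives only a limit, > 100000 nM, so it has no exact value. Its neighbour, compound 3 `O=C(Nc1ccccc1Cl)c1ccc(Nc2ncnc3c2cnn3-c2ccc(Cl)cc2)cc1`, has not yet been measured. It carries 2-chlorophenyl in place of cyclohexyl on an amide-type nitrogen.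

Within the data shown here, only one measured step bears on this change: an at least 11-fold higher number from compound 1 to compound 2 (1.04 log units; beyond the scatter), with cyclohexylcarbamoyl in place of ((2-chlorophenyl)carbamoyl)amino on an aromatic carbon. That step is large, but it changes more than the group now in question, and its true size is bounded only from one side. Compound 3 shares its 2-chlorophenyl with compound 1, which gives 9050 nM, and its amide link with compound 2. A result between the two is therefore expected, with a lower number than the limit of compound 2 but probably not as low as the value of compound 1. Another limit in this assay remains possible. The expected size of the change is an at least 3.3-fold lower number from compound 2 to compound 3 (0.52 log units; beyond the scatter). The estimate for compound 3 is 30000 nM, with an expected range from 9000 nM to 100000 nM.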

Compound 3, half-maximal inhibitory concentration: > 100000 nM
Compound 3: a limit, no number; the forecaster's own chance of this, stated with the estimate: 30%; middle value at least 3.3-fold (0.52 log units) from the limit.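

The step from compound 2 to compound 3 cannot be read because both of its ends are limits of the assay: the limit of > 100000 nM in this assay, at which 2 of the 3 values shown sit.

With 2-chlorophenyl now the same on both sides, the change from ((2-chlorophenyl)carbamoyl)amino to (2-chlorophenyl)carbamoyl on an aromatic carbon gives an at least 11-fold higher number from compound 1 to compound 3 (1.04 log units; beyond the scatter). The earlier step, an at least 11-fold higher number from compound 1 to compound 2 (1.04 log units; beyond the scatter), also exchanged the end group, whereas the new step shows that a loss reaching the limit in this assay appears even with 2-chlorophenyl kept and cyclohexyl absent.

Going by these compounds, how far compound 2 and compound 3 truly lie from each other stays open, as does whether 2-chlorophenyl and cyclohexyl differ at all on this amide-type nitrogen. On these data alone, it is also open whether a longer chain ending in an amine on that nitrogen would give an exact value in this assay, and whether cyclohexyl in place of 2-chlorophenyl in compound 1 would keep a measurable value.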